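A few compounds are considered here, and "the series" means these few. Any claim that something is new, unique, unknown or untested is made for them only; others in the source may bear on it.

Series notes. In a functional assay on Caco-2 cells (Homo sapiens) for inhibition, read by MTT assay, with a stated time of 48 h, tested at 10 uM (on this read-out higher numbers stand for more inhibition of growth at the one concentration tested and lower numbers for less inhibition of growth), compound 1 `COc1ccc(COc2cc(O)c3c(=O)cc(C)oc3c2[C@H]2CCN(C)C[C@H]2O)cc1` gives 8% and compound 2 `Cc1cc(=O)c2c(O)cc(OCc3ccc([N+](=O)[O-])cc3)c([C@H]3CCN(C)C[C@H]3O)c2o1` gives 14%. Compound 3 `Cc1cc(=O)c2c(O)c(CN3CCC(N4CCCCC4)CC3)c(O)c([C@H]3CCN(C)C[C@H]3O)c2o1` gives 31%, the highest of the three numbers and beyond the scatter of both others. Compound 4 `Cc1cc(=O)c2c(O)c(CN3CCC(c4ccccc4)CC3)c(O)c([C@H]3CCN(C)C[C@H]3O)c2o1` is still unmeasured and differs from compound 3 in one place: phenyl in place of piperidin-1-yl on a saturated ring carbon. Going by the values given here, the only measured single-place step is a number 6 percentage points higher from compound 1 to compound 2 (within the scatter), which lies within the scatter. That step is nitro in place of methoxy on an aromatic carbon, a different exchange at a different place, so it bears only weakly on this one. Among the compounds with values here, no measured step covers the exchange itself, and the data give no direction for it. No change beyond the scatter is expected in this assay, so the expectation stays near compound 3 at 31%. The expected step is a number 1 percentage points lower from compound 3 to compound 4 (within the scatter), an estimate with wide uncertainty. For compound 4 the estimate is 30%, with an expected range from 14% to 48%.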

Compound 4, percent growth inhibition at one concentration: 21%
For compound 4 the middle estimate is 9 percentage points above the measured one; the range from low to high includes it.
By their numbers in this assay, from the lowest: compounds 1, 2, 4 and 3 (each within the scatter of the next, the first and the last beyond it).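

In this assay, going by these compounds alone, phenyl in place of piperidin-1-yl on a saturated ring carbon, three ring bonds from the ring nitrogen, gives the first reading at this position (a number 10 percentage points lower from compound 3 to compound 4 (within the scatter)). The exchange swaps a six-membered non-aromatic ring holding a nitrogen and a hydrogen-bond acceptor for an aromatic ring of carbon only, and the step stays within the scatter, so this read-out does not separate the two groups. No supporting data on either group bear on this step, and it is given here without a cause.

The compounds shown leave open how a morpholine ring, a primary amine or a carboxylic acid on this ring carbon would read. They also leave open whether any exchange here can produce a step beyond the scatter.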